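The source may report more compounds than this note shows. Statements on the series, on what has been measured and on what is new or still open speak of the compounds shown alone.

Measured compounds:
- compound 2 `O=C(Nc1cccc(I)c1)C(Cl)Cl` — 58800 nM in a functional assay on BGC-823 cells (Homo sapiens) for antiproliferative activity, read by MTT assay, with a stated time of 72 h; a lower number here means a stronger inhibitor, a higher number a weaker inhibitor
- compound 1 `O=C(Nc1cccc(F)c1)C(Cl)Cl` — "not determined" (no result reported) in this assay

Going by the values given here, compound 2 therefore stands as the only compound of the pair with a number, and that number marks it as a weak inhibitor; compound 1 gives nothing to compare against. Compound 3 `COc1cccc(NC(=O)C(Cl)Cl)c1` arises from compound 2 by methoxy in place of iodo on an aromatic carbon. Among the compounds with values here, with no measured step available to anchor the direction, the expectation is a small move, if any, toward weaker inhibition, roughly a 1.4-fold higher number from compound 2 to compound 3 (0.13 log units; within the scatter). Compound 3 is accordingly estimated at 80000 nM, with a range from 25000 nM to 250000 nM.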

Compound 3, half-maximal inhibitory concentration: 179000 nM
For compound 3 the middle estimate is 2.2-fold (0.35 log units) below the measured one; measured number inside the range.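

In this assay, going by these compounds alone, methoxy in place of iodo on an aromatic carbon, meta to a group of 6 heavy atoms, gives a 3.0-fold higher number from compound 2 to compound 3 (0.48 log units; beyond the scatter) as the only readable step. This position therefore responds to the change, and this exchange moves toward weaker inhibition. No measurement at hand explains that move.

Compound 1 has no result, so the fluoro compound offers no further comparison. On these data alone, how an amine, a carboxylic acid or a longer chain at this position would read remains open.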